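The compounds below may be only part of what the source reports. "The series", "measured", "known", "first", "only" and "open" are said of these compounds alone.

Measured compounds:
- compound 1, `O=C(c1ncc(-c2ccccn2)o1)[C@@H]1COc2cc(OCc3ccccc3)ccc2C1`: 17 nM
- compound 2, `O=C(c1ncco1)C1COc2cc(Oc3ccccc3)ccc2C1`: 33 nM
- compound 3, `O=C(c1ncco1)C1CCc2cc(Oc3ccccc3)ccc2O1`: 17 nM; 31 nM (2 entries)

In an assay for inhibition of Fatty-acid amide hydrolase 1 (Rattus norvegicus), using a Dixon plot (on this read-out higher numbers stand for weaker inhibition and lower numbers for stronger inhibition), compound 1 gives 17 nM, the lowest of the two single numbers given here; compound 2 gives 33 nM, a gap that lies within the usual scatter, so neither can be set above the other. Compound 3 has more than one entry in this assay, (the several entries of compound 3 in this assay, 17 nM; 31 nM (2 entries)), and these spread over a range of the same size as that gap, which shows how wide the scatter of such measurements runs.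

The account now turns from compound 1 to compound 4, `O=C(c1ncc(-c2ccccn2)o1)[C@H]1COc2cc(OCc3ccccc3)ccc2C1`, not yet measured in this assay. The change is the two compounds have the same atoms and bonds and differ only in configuration as drawn: 1 of 1 stereo elements differ; a stereocentre at a saturated ring carbon is drawn S in compound 1 and R in compound 4. For the measured compounds named here, no measured pair in this set shows what a change of this kind does, so the step from compound 1 to compound 4 is expected rather than known; in the writer's estimate a weaker inhibition is the more likely outcome, with wide uncertainty in either direction. Compound 4 is therefore expected to give 120 nM in this assay, within 20 nM to 1500 nM, which means an expected step of a 7.1-fold higher number from compound 1 to compound 4 (0.85 log units; beyond the scatter).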

Compound 4, inhibition constant: 18 nM
Beside the measured number, compound 4's estimate is 6.7-fold (0.82 log units) above it; the whole stated range lies above it.
By their numbers in this assay, from the lowest: compounds 1, 4 and 2 (each within the scatter of the next).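

In this assay, for the compounds shown here, the change of configuration at the saturated ring carbon gives the first step in this set between compounds that differ in one place: a 1.1-fold higher number from compound 1 to compound 4 (0.02 log units; within the scatter). This shows that the S and R forms as drawn at this stereocentre cannot be told apart on this read-out, at least on the core of compound 1. The step is also smaller than the spread seen for a single compound: the several entries of compound 3 in this assay, 17 nM; 31 nM (2 entries).

From the compounds shown here alone, whether this stereocentre stays equally silent when a carboxylic acid or an amine sits on the core of compound 1 remains open. Compound 2 and compound 3 are drawn without a defined configuration, so the compounds shown do not tell whether their two forms would also match.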